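Furan isomer change on the methoxy pyrrolopyrimidine nucleoside core

The source may report more compounds than this note shows. Statements on the series, on what has been measured and on what is new or still open speak of the compounds shown alone.

Compound 3 `COc1ncnc2c1c(-c1ccco1)cn2[C@@H]1O[C@H](CO)[C@@H](O)[C@H]1O` gives 1020 nM in a functional assay on HeLa S3 cells (Homo sapiens) for antiproliferative activity, read by XTT assay, with a stated time of 72 h; on this read-out lower numbers stand for stronger inhibition and higher numbers for weaker inhibition. Among the numbers shown it holds the lowest figure, with compound 1 `COc1ncnc2c1c(-c1cccs1)cn2[C@@H]1O[C@H](CO)[C@@H](O)[C@H]1O` nearest at 1760 nM; the move a 1.7-fold lower number from compound 1 to compound 3 (0.24 log units; within the scatter) keeps both within the scatter of repeated measurements. Compound 2 `Nc1nc(N)c2c(-c3ccoc3)cn([C@@H]3O[C@H](CO)[C@@H](O)[C@H]3O)c2n1` returns only a limit in this assay, > 20000 nM, as recorded in the limit of > 20000 nM in this assay, at which 1 of the 3 values shown sits.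

Compound 4 `COc1ncnc2c1c(-c1ccoc1)cn2[C@@H]1O[C@H](CO)[C@@H](O)[C@H]1O` is the next member. Its change from compound 3 is furan-3-yl in place of furan-2-yl on an aromatic carbon. Within the data shown here, compound 2 also carries a furan-3-yl group, but on a core that differs elsewhere, so no measured step describes moving from furan-2-yl to furan-3-yl on an otherwise unchanged core. Among the measured compounds shown here, the only single-point step measured here, from thiophen-2-yl to furan-2-yl, stayed within the scatter, which shows that swapping one five-membered heteroaryl for another at this aromatic carbon can leave this assay largely unmoved. A shift of the heteroatom within the ring is a different kind of change, and no shown step sizes it.

Compound 4 is therefore expected to give about 2000 nM in this assay, with a range from 600 nM to 7000 nM. The expected step of a 2.0-fold higher number from compound 3 to compound 4 (0.29 log units; within the scatter) is set near the scatter, leaning toward a higher number, with the limit seen for compound 2 kept in mind as a possible outcome.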

Compound 4, half-maximal inhibitory concentration: 1790 nM
For compound 4 the middle estimate is 1.1-fold (0.05 log units) above the measured one; the range from low to high includes it.
By their numbers in this assay, from the lowest: compounds 3, 1 and 4 (each within the scatter of the next). At a limit, above all of these: compound 2.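

In this assay, among these compounds, moving the attachment point of the furan ring gives a 1.8-fold higher number from compound 3 to compound 4 (0.24 log units; within the scatter), the first measured step in which the ring stays the same and only its point of attachment changes. Replacing thiophen-2-yl with furan-3-yl gives a 1.0-fold higher number from compound 1 to compound 4 (0.01 log units; within the scatter), so on the shared core the thiophen-2-yl, furan-2-yl and furan-3-yl groups all lie within the scatter of one another in this assay. At this aromatic carbon, two ring bonds from the ring nitrogen, neither the identity of the ring hetero atom nor the attachment point of the furan separates these three compounds, and nothing on hand bears on why this read-out stays flat across them.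

Going by these compounds, all the groups at this carbon are five-membered aromatic rings with 1 hetero atom, so it remains open how the read-out would respond to a phenyl ring, an aminomethyl group or a longer alkyl chain there. On these data alone, compound 2 gives only a limit, > 20000 nM, on a core that differs elsewhere, so the contribution of the methoxy group on the shared core also remains open.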